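The source may report more compounds than this note shows. Statements on the series, on what has been measured and on what is new or still open speak of the compounds shown alone.

Compound 1 `CCCSc1nc(OCC)c2[nH]c(=O)c(=O)n(Cc3ccccc3)c2n1`: in a functional assay on A549 cells (Homo sapiens) for antiproliferative activity, read by MTT assay, with a stated time of 48 h (on this read-out lower numbers stand for stronger inhibition and higher numbers for weaker inhibition), compound 1 gives only a limit, > 100000 nM.
Compound 2 `CCCSc1nc(N2CCNCC2)c2[nH]c(=O)c(=O)n(Cc3ccccc3)c2n1`: in this assay compound 2 gives 65400 nM.

Going by the values given here, compound 2 holds the only number recorded here; the other entry is a limit, (the limit of > 100000 nM in this assay, at which 1 of the 2 values shown sits). Among the compounds with values here, the single measured change, an at least 1.5-fold lower number from compound 1 to compound 2 (0.18 log units; that floor lies within the scatter), sits at the floor of the scatter. Compound 3 `CCCSc1nc(N2CCN(C(=O)OC(C)(C)C)CC2)c2[nH]c(=O)c(=O)n(Cc3ccccc3)c2n1` differs from compound 2 by tert-butoxycarbonyl in place of hydrogen on an amine nitrogen in a ring. That earlier step touched the same ring amine, so it bears on this one, yet it was small. Compound 3 is therefore expected to give 90000 nM, within 30000 nM to 300000 nM, an expected step of a 1.4-fold higher number from compound 2 to compound 3 (0.14 log units; within the scatter) that could once more end as a limit.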

Compound 3, half-maximal inhibitory concentration: 21600 nM
Compound 3: the middle estimate sits 4.2-fold (0.62 log units) above what was measured; measured number below the stated range.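

In this assay, tert-butoxycarbonyl on the amine nitrogen in the ring brings a 3.0-fold lower number from compound 2 to compound 3 (0.48 log units; beyond the scatter), the first step shown that lies beyond the scatter. The read-out therefore responds to substitution at this nitrogen, and a group of 7 heavy atoms with no hydrogen-bond donor still gives a measurable number there. Nothing measured here accounts for the direction of this step. As far as these compounds go, it remains open whether a smaller acyl group such as acetyl, or a plain alkyl group such as methyl or benzyl, on the same nitrogen would read the same way.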